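Removing the Methyl from the Ring Nitrogen of Compound 2

This account rests on a few compounds, and the source may have more. Where it says the series, first, only, none or still open, it means among the compounds named here.

Of the compounds shown here, three built on one shared amide-bearing core have been tested in an assay on isolated protein for inhibition of Rho-associated protein kinase 1 (Homo sapiens); on this read-out lower numbers stand for stronger inhibition and higher numbers for weaker inhibition. Compound 1 `COc1cccc(CNC(=O)c2cn(C)c3nc(-c4cn[nH]c4)ccc23)c1` reaches the floor of the assay: in this assay compound 1 gives < 1 nM, which is a limit and not a number. Compound 2 `COc1cccc(CNC(=O)c2cn(C)c3cc(-c4cn[nH]c4)ccc23)c1` is a close analogue of compound 1; in this assay compound 2 likewise gives < 1 nM, again a limit of the assay rather than a measured number. Compound 3 `COc1cccc(CNC(=O)c2[nH]c3nc(-c4cn[nH]c4)ccc3c2CN2CCN(C)CC2)c1`, which carries an additional side chain on its core and no methyl on the ring nitrogen, is the only one with a numerical result: in this assay compound 3 gives 39 nM. Compound 2 thus sits where the assay can resolve nothing further, a position it shares with compound 1 (the limit of < 1 nM in this assay, at which 2 of the 3 values shown sit), while compound 3 shows a higher number.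

Compound 4 `COc1cccc(CNC(=O)c2c[nH]c3cc(-c4cn[nH]c4)ccc23)c1` has not yet been measured. It arises from compound 2 by hydrogen in place of methyl on an aromatic nitrogen. Among the measured compounds shown here, no measured pair isolates this change, and compound 3 differs from the others in more than one place, so its value cannot be assigned to the missing methyl alone. Compound 4 is expected to remain very potent, estimated at 1.5 nM, between 0.3 nM and 6 nM. This estimate corresponds to an expected step of an at least 1.5-fold higher number from compound 2 to compound 4 (0.17 log units; that floor lies within the scatter), within the usual scatter.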

Compound 4, half-maximal inhibitory concentration: < 1 nM
Compound 4 gave a limit, no number (the forecaster's own chance of this, stated with the estimate: 45%); middle value at least 1.5-fold (0.17 log units) away from the limit.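

In this assay compound 4 gives < 1 nM as a limit of the assay and not a number. Compound 2 stands at a limit too, so no step can be read from compound 2 to compound 4: the limit of < 1 nM in this assay, at which 3 of the 4 values shown sit. The compounds shown leave open whether hydrogen in place of methyl on this aromatic nitrogen changes the inhibition at all.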